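Adding methyl to the 3-cyanocyclobutyl group of compound 2

This account rests on a few compounds, and the source may have more. Where it says the series, first, only, none or still open, it means among the compounds named here.

Among the compounds with values here, in an ADME assay on MDCKII-LE cells (Canis lupus familiaris) for permeability (on this read-out higher numbers stand for higher permeability and lower numbers for lower permeability), compound 1 (`N#CCCCCN([C@H](CCC(F)(F)F)C(N)=O)S(=O)(=O)c1ccc(Cl)cc1`) gives 24 10^-6 cm/s and compound 2 (`N#C[C@H]1C[C@@H](CN([C@H](CCC(F)(F)F)C(N)=O)S(=O)(=O)c2ccc(Cl)cc2)C1`) gives 24.1 10^-6 cm/s, so compound 2 stands level with compound 1, the only other measured compound. Within the data shown here, the single measured step, a 1.0-fold higher number from compound 1 to compound 2 (0.00 log units; within the scatter), lies within the scatter. Compound 3 (`C[C@]1(C#N)C[C@H](CN([C@H](CCC(F)(F)F)C(N)=O)S(=O)(=O)c2ccc(Cl)cc2)C1`) carries methyl in place of hydrogen on a saturated ring carbon. Among the measured compounds shown here, no measured step covers this change directly, so no shift beyond the scatter is expected. The expected step is a 1.0-fold higher number from compound 2 to compound 3 (0.02 log units; within the scatter). For compound 3 the estimated value is 25 10^-6 cm/s, with an expected range of 14 10^-6 cm/s to 42 10^-6 cm/s.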

Compound 3, apparent permeability: 21.8 10^-6 cm/s
Estimate against measurement, compound 3: 1.1-fold (0.06 log units) above, and the stated range covers the measured number.
By their numbers in this assay, from the lowest: compounds 3, 1 and 2 (each within the scatter of the next).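

In this assay the added methyl on the saturated ring carbon of the four-membered ring gives a 1.1-fold lower number from compound 2 to compound 3 (0.04 log units; within the scatter) and so moves the read-out no further than the scatter. Against the open chain, the 3-cyano-3-methylcyclobutyl group gives a 1.1-fold lower number from compound 1 to compound 3 (0.04 log units; within the scatter) and likewise stays within the scatter, so all three compounds stand level. No measurement bears on why this ring carbon tolerates the methyl. Still open, going by these compounds, is whether a larger group on this carbon, such as an ethyl or a phenyl, would stay level, and whether an amine or a carboxylic acid in place of the nitrile would do so.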